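From compound 3 to compound 4: one group exchanged

This account rests on a few compounds, and the source may have more. Where it says the series, first, only, none or still open, it means among the compounds named here.

compound 1 `COc1ccc(C(F)(F)F)cc1Nc1ncc(C(F)(F)F)c(N2Cc3cccc(N(C)S(C)(=O)=O)c3C2)n1`: > 30000 nM (a limit)
compound 2 `CN(c1cccc2c1CN(c1nc(Nc3ccc(C(F)(F)F)cc3)ncc1C(F)(F)F)C2)S(C)(=O)=O`: > 30000 nM (a limit)
compound 3 `Cc1cc(Cl)ccc1Nc1ncc(C(F)(F)F)c(N2Cc3cccc(N(C)S(C)(=O)=O)c3C2)n1`: 28300 nM

These compounds share one core and differ only in the group on a nitrogen on an aromatic ring. All were tested in a functional assay on U-87MG ATCC cells for antiproliferative activity against U-87 MG (Homo sapiens), read by spectrophotometry, with a stated time of 2 days; on this read-out higher numbers stand for weaker inhibition of growth and lower numbers for stronger inhibition of growth. Among the compounds with values here, compound 3 gives 28300 nM, the only true number of the three. Both compound 1 and compound 2 stand at the limit of > 30000 nM in this assay, at which 2 of the 3 values shown sit, which is a limit and not a number.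

In compound 4 `COc1cc(Nc2ncc(C(F)(F)F)c(N3Cc4cccc(N(C)S(C)(=O)=O)c4C3)n2)cc(C(F)(F)F)c1`, 3-methoxy-5-(trifluoromethyl)phenyl takes the place of 4-chloro-2-methylphenyl on a nitrogen on an aromatic ring: 3-methoxy-5-(trifluoromethyl)phenyl in place of 4-chloro-2-methylphenyl on a nitrogen on an aromatic ring.

Within the data shown here, earlier exchanges at this same place offer the only guide: an at least 1.0-fold lower number from compound 1 to compound 3 (0.02 log units; that floor lies within the scatter) and an at least 1.0-fold lower number from compound 2 to compound 3 (0.02 log units; that floor lies within the scatter). Both are floors within the scatter, so neither gives a true size. A third step, a step that the two limits leave unreadable from compound 1 to compound 2, cannot be sized at all. No step beyond the scatter is therefore expected in this assay, in either direction, and the result may well be reported as another limit. The expected change is a 1.1-fold higher number from compound 3 to compound 4 (0.03 log units; within the scatter). For compound 4 the estimated value is 30000 nM, with an expected range from 13000 nM to 70000 nM.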

Compound 4, concentration for 50% growth inhibition: > 30000 nM
Compound 4: only a limit was reported; the forecaster's own chance of this, stated with the estimate: 60%; the middle value lies on the limit itself.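

Putting 3-methoxy-5-(trifluoromethyl)phenyl in place of 4-chloro-2-methylphenyl on this nitrogen adds a hydrogen-bond acceptor, yet the result is an at least 1.0-fold higher number from compound 3 to compound 4 (0.02 log units; that floor lies within the scatter). The steps from compound 1 and from compound 2 to compound 4 cannot be read, as both ends of each are limits. In this assay, compound 3 remains the only compound with a true number, and a third substituted phenyl group now shares one reading: the limit of > 30000 nM in this assay, at which 3 of the 4 values shown sit.

As far as these compounds go, all four compounds carry a substituted phenyl group at this place, so it stays open whether a phenyl group bearing a carboxylic acid or an amine, or a morpholine in its place, would give a clearly lower number. From the compounds shown here alone, how changes elsewhere on the shared core would affect growth inhibition also stays open.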